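From dimethylphenyl to naphthalenyl on the sulfur

The compounds below may be only part of what the source reports. "The series", "measured", "known", "first", "only" and "open" are said of these compounds alone.

Measured so far in a functional assay on U2OS cells (Homo sapiens) for antiproliferative activity, read by MTT assay, with a stated time of 72 h (on this read-out higher numbers stand for weaker inhibition and lower numbers for stronger inhibition), are three compounds

- compound 1 `O=C(CSc1ncc[nH]1)Nc1ccc2nc(NC(=O)c3ccc(C(F)(F)F)cc3)sc2c1` gives 18800 nM
- compound 2 `O=C(CSc1ncccn1)Nc1ccc2nc(NC(=O)c3ccc(C(F)(F)F)cc3)sc2c1` gives 28100 nM
- compound 3 `Cc1ccc(SCC(=O)Nc2ccc3nc(NC(=O)c4ccc(C(F)(F)F)cc4)sc3c2)c(C)c1` gives 1000 nM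

Compound 3 has the lowest number of the three, which makes it the strongest inhibitor here. Compound 4 `O=C(CSc1ccc2ccccc2c1)Nc1ccc2nc(NC(=O)c3ccc(C(F)(F)F)cc3)sc2c1` is not yet measured and differs from it in one group: naphthalen-2-yl in place of 2,4-dimethylphenyl on a sulfur sits in place of 2,4-dimethylphenyl on a sulfur. Among the measured compounds shown here, two measured steps bear on this group, a 19-fold lower number from compound 1 to compound 3 (1.27 log units; beyond the scatter) and a 28-fold lower number from compound 2 to compound 3 (1.45 log units; beyond the scatter), and both are large. Each brought in 2,4-dimethylphenyl, whereas a 1.5-fold higher number from compound 1 to compound 2 (0.17 log units; within the scatter) shows no real change. Neither covers an exchange of one all-carbon aromatic group for another, so only a small change is expected in this assay here. The estimated change is a 1.2-fold higher number from compound 3 to compound 4 (0.08 log units; within the scatter) on this read-out. Compound 4 is expected at 1200 nM with a range from 400 nM to 4000 nM as the estimate.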

Compound 4, half-maximal inhibitory concentration: 3940 nM
Estimate against measurement, compound 4: 3.3-fold (0.52 log units) below; low and high end bracket the measured number.
By their numbers in this assay, from the lowest: compound 3; then compound 4; then compounds 1 and 2 (each within the scatter of the next).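

Exchanging one all-carbon aromatic group for another on the sulfur still matters in this assay, with a 3.9-fold higher number from compound 3 to compound 4 (0.60 log units; beyond the scatter) as the result. Naphthalen-2-yl keeps part of the gain over the two nitrogen-containing rings, with a 7.1-fold lower number from compound 2 to compound 4 (0.85 log units; beyond the scatter) for pyrimidin-2-yl and a 4.8-fold lower number from compound 1 to compound 4 (0.68 log units; beyond the scatter) for 1H-imidazol-2-yl as the comparisons. Nothing measured here gives a reason for these steps.

On these data alone, whether the gain depends on the two methyl groups, or on an aromatic ring at all, stays open. A plain phenyl or a cyclohexyl group on the sulfur would help separate these possibilities.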